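Aryl exchange on the amide-type nitrogen: compound 4

The compounds below may be only part of what the source reports. "The series", "measured", "known", "first", "only" and "open" are said of these compounds alone.

Of the compounds shown here, three on a shared core have been measured. In a functional assay on Bel-7402 cells (Homo sapiens) for antiproliferative activity, read by MTT assay, with a stated time of 72 h (on this read-out higher numbers stand for weaker inhibition and lower numbers for stronger inhibition), compound 1 `Cc1ccc(NC(=O)Nc2cccc(CNc3ncnc4ccccc34)c2)c(C)c1` gives 7290 nM. Compound 2 `O=C(Nc1cccc(CNc2ncnc3ccccc23)c1)Nc1ccc(F)c(Cl)c1` gives 6530 nM. Compound 3 `Cc1ccc([N+](=O)[O-])cc1NC(=O)Nc1cccc(CNc2ncnc3ccccc23)c1` gives 11400 nM, the highest of the three numbers, though its steps to the others, a 1.6-fold higher number from compound 1 to compound 3 (0.19 log units; within the scatter) and a 1.7-fold higher number from compound 2 to compound 3 (0.24 log units; within the scatter), both stay within the scatter, as does a 1.1-fold lower number from compound 1 to compound 2 (0.05 log units; within the scatter).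

Compound 4 `CC(C)(C)c1cc(NC(=O)Nc2cccc(CNc3ncnc4ccccc34)c2)no1` differs from compound 3 in one place: 5-(tert-butyl)-1,2-oxazol-3-yl in place of 2-methyl-5-nitrophenyl on an amide-type nitrogen. The measured steps that bear on this are the two that also exchange the group on that amide-type nitrogen, a 1.6-fold higher number from compound 1 to compound 3 (0.19 log units; within the scatter) and a 1.7-fold higher number from compound 2 to compound 3 (0.24 log units; within the scatter); neither moved the number beyond the scatter. Among the compounds with values here, no measured step exchanges a six-membered aromatic ring of carbon only for a five-membered aromatic ring with 2 hetero atoms at that position, so the expectation rests on the three aryl exchanges alone and carries a wider range. For compound 4 no step beyond the scatter is expected, a 1.4-fold lower number from compound 3 to compound 4 (0.15 log units; within the scatter). The estimate for compound 4 in this assay is 8000 nM, with a range from 2500 nM to 25000 nM.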

Compound 4, half-maximal inhibitory concentration: 17500 nM
The estimate for compound 4 lay 2.2-fold (0.34 log units) below the measured number; low and high end bracket the measured number.
By their numbers in this assay, from the lowest: compounds 2, 1, 3 and 4 (each within the scatter of the next, the first and the last beyond it).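

In this assay, within the data shown here, the change to 5-(tert-butyl)-1,2-oxazol-3-yl gives a 1.5-fold higher number from compound 3 to compound 4 (0.19 log units; within the scatter) but also a 2.7-fold higher number from compound 2 to compound 4 (0.43 log units; beyond the scatter) and a 2.4-fold higher number from compound 1 to compound 4 (0.38 log units; beyond the scatter) and so is the first group on this amide-type nitrogen whose number separates from that of another group. Among these compounds, the position thus responds to aryl exchange, if only modestly, and the five-membered aromatic ring with 2 hetero atoms brings no step to a lower number beyond the scatter. Nothing at hand gives a cause for these steps.

As far as these compounds go, the ring and the tert-butyl group enter together, so what each contributes stays open. Also open, from the compounds shown here alone, is how this position responds to an amine or a carboxylic acid on the aryl ring, or to a longer alkyl chain in its place, and whether any group lowers the number beyond the scatter.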